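Hydroxyacyl side chain: 1-methylcyclopropyl versus isobutyl

The source may report more compounds than this note shows. Statements on the series, on what has been measured and on what is new or still open speak of the compounds shown alone.

Measured so far:
compound 1 `O=C(NCc1cc(Cl)ccc1-n1cnnn1)[C@@H]1[C@H]2C[C@H]2CN1C(=O)[C@H](O)CC1CC1`; in a functional assay on a cell-free system (plasma, Homo sapiens), with a stated time of 3 min (a higher number here means a weaker inhibitor, a lower number a stronger inhibitor), compound 1 gives 1400 nM
compound 2 `CC1(C[C@@H](O)C(=O)N2N=CC[C@H]2C(=O)NCc2cc(Cl)ccc2-n2cnnn2)CC1`; in this assay compound 2 gives 730 nM

Compound 2 holds the lower of the two numbers, with compound 1 at a number higher by an amount that is within the scatter, so no order between the two can be read from them. Compound 3 `CC(C)CC[C@@H](O)C(=O)N1N=CC[C@H]1C(=O)NCc1cc(Cl)ccc1-n1cnnn1` keeps the core of compound 2 and differs only in the side chain: isobutyl in place of 1-methylcyclopropyl on a saturated chain carbon, two bonds along the chain from a carbonyl carbon and an oxygen on a saturated carbon. Among the compounds with values here, no measured pair in the set isolates this kind of change, so there is no step to lean on. The leaving and entering groups match in what is counted for them, differing only in that the ring is gone, so the change is expected to move the number little, if at all beyond the scatter, with a slight lean toward a higher number. Compound 3 is expected to give 950 nM (range 400 nM to 2300 nM), which amounts to an expected step of a 1.3-fold higher number from compound 2 to compound 3 (0.11 log units; within the scatter).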

Compound 3, half-maximal inhibitory concentration: 630 nM
Compound 3: the middle estimate sits 1.5-fold (0.18 log units) above what was measured; the measured number falls inside the stated range.
By their numbers in this assay, from the lowest: compounds 3, 2 and 1 (each within the scatter of the next, the first and the last beyond it).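

In this assay, within the data shown here, replacing 1-methylcyclopropyl with isobutyl at this saturated chain carbon gives a 1.2-fold lower number from compound 2 to compound 3 (0.06 log units; within the scatter) as the first single-place step. With the core of compound 2 held fixed, the ring of the 1-methylcyclopropyl group can be exchanged for the open isobutyl chain without the number leaving the scatter, so this read-out does not tell the two groups apart at this position. No data shown here bear on why the two groups read alike.

Still open, from the compounds shown here alone, is whether an amine, a carboxylic acid or a longer chain at this place would move the number beyond the scatter. Also open, going by these compounds, is whether the same change would read alike on the core of compound 1.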